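A few compounds are considered here, and "the series" means these few. Any claim that something is new, unique, unknown or untested is made for them only; others in the source may bear on it.

Measured in an assay for inhibition of Indoleamine 2,3-dioxygenase 1 (Homo sapiens), with a stated time of 1 h, tested at 10 uM; a higher number here means more inhibition at the concentration tested (going by the name of the read-out), a lower number less inhibition:

compound 1 `ONc1cccc(CNc2cc(Br)cc3[nH]ncc23)c1`, 53%
compound 2 `CC(Nc1cc(Br)cc2[nH]ncc12)c1ccc([N+](=O)[O-])cc1`, 17%
compound 3 `Cc1cc(O)ccc1CNc1cc(Br)cc2[nH]ncc12`, 60%

Compound 1 sits second of the three numbers in this assay. Its nearest neighbour is compound 3, whose number lies higher by an amount within the usual scatter, so the two cannot be told apart on these data. For the measured compounds named here, compound 2 lies well below compound 1, and that gap is beyond the scatter; compound 2 also carries a different substituent pattern on the shared core, and no single-change step between measured compounds exists in this set to attribute the gap to any one feature.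

Compound 4 `OC1CCCC(Nc2cccc(CNc3cc(Br)cc4[nH]ncc34)c2)C1` keeps the core of compound 1 and differs from it as follows: 3-hydroxycyclohexyl in place of hydroxy on a nitrogen on an aromatic ring. The nitrogen in question is left with the same donor and acceptor count; a six-membered non-aromatic ring of carbon only replaces the single oxygen. Going by the values given here, no measured pair shows what such a change does in this assay, so the expected step is hedged. The step from compound 1 to compound 4 is expected to be small, with a number 3 percentage points lower from compound 1 to compound 4 (within the scatter) not clearly beyond the scatter in either direction. Compound 4 is therefore estimated at 50%, with a range from 25% to 75%.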

Compound 4, a percentage reported as inhibition, at one concentration (the size of the read-out at that concentration, not a potency): 52%
Estimate against measurement, compound 4: 2 percentage points below, and the stated range covers the measured number.
By their numbers in this assay, from the lowest: compound 2; then compounds 4, 1 and 3 (each within the scatter of the next).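

In this assay, 3-hydroxycyclohexyl in place of hydroxy on a nitrogen on an aromatic ring gives a number 1 percentage points lower from compound 1 to compound 4 (within the scatter), the first single-change step available in this series. The earlier compounds shown here gave no reading at this position, and this step shows that the read-out at the tested concentration does not separate the small hydroxy from the much larger group with its six-membered non-aromatic ring of carbon only, with the same count of hydrogen-bond donors and acceptors on both sides of the change. No independent information is available to explain this outcome, so the step stands only as an observation on this pair.

Open, going by these compounds, is whether the hydroxy on the new ring matters at all or whether the ring alone is enough, a question that plain cyclohexyl on the same nitrogen would address, with a primary amine or a carboxylic acid on that ring as further probes of the same place. Also open, on these data alone, is whether any single change at this nitrogen, such as a longer alkyl chain or an unsubstituted amino group in place of hydroxyamino, moves the number beyond the scatter in either direction.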